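A few compounds are considered here, and "the series" means these few. Any claim that something is new, unique, unknown or untested is made for them only; others in the source may bear on it.

For the measured compounds named here, in a functional assay on A549 cells (Homo sapiens) for inhibition, read by colorimetric assay and sulforhodamine B assay, with a stated time of 48 h (a higher number here means a weaker inhibitor of growth, a lower number a stronger inhibitor of growth), compound 2 (`CCCCCCCCCCCC[C@@H](O)[C@H]1CC[C@H]([C@H](O)CCCCCCCCCCNC(=O)c2ccco2)O1`) gives 100000 nM as its concentration for half growth inhibition, the higher of the two numbers measured so far. That makes it the weaker growth inhibitor of the pair. Compound 1 (`CCCCCCCCCCCC[C@@H](O)[C@H]1CC[C@H]([C@H](O)CCCCCCCCCCNC(=O)c2cccs2)O1`) gives 3720 nM in the same test and differs only in the group on the carbonyl carbon.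

Compound 3 (`CCCCCCCCCCCC[C@@H](O)[C@H]1CC[C@H]([C@H](O)CCCCCCCCCCNC(=O)c2ccoc2)O1`) keeps the rest of compound 2 and has the same atoms, joined differently. The change is furan-3-yl in place of furan-2-yl, and the details are furan-3-yl in place of furan-2-yl on a carbonyl carbon in this one place.

Going by the values given here, only one measured step bears on this site: replacing thiophen-2-yl with furan-2-yl gave a 27-fold higher number from compound 1 to compound 2 (1.43 log units; beyond the scatter) on that same carbonyl carbon. So a swap here can matter greatly, although furan-3-yl itself has no measurement yet. With compound 2 at 100000 nM as the higher number, a fall seems likelier than a rise. The expected change is an estimated 5.0-fold lower number from compound 2 to compound 3 (0.70 log units; beyond the scatter) and remains very uncertain. For compound 3 the expected value is 20000 nM with an estimated range from 3000 nM to 120000 nM in this test.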

Compound 3, concentration for 50% growth inhibition: 100000 nM
Estimate against measurement, compound 3: 5.0-fold (0.70 log units) below, and the stated range covers the measured number.
By their numbers in this assay, from the lowest: compound 1; then compounds 2 and 3 (each within the scatter of the next).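

Moving the attachment point on the furan ring while keeping the same atoms gives no change at the digits printed from compound 2 to compound 3 (within the scatter) in this assay, so at this carbonyl carbon furan-2-yl and furan-3-yl cannot be told apart in this test. The earlier pair showed only that one furan differed from thiophen-2-yl, but the same gap now appears for the second furan, with a 27-fold higher number from compound 1 to compound 3 (1.43 log units; beyond the scatter), which places both furans on the weaker side of compound 1 among these three compounds. Nothing available explains why the thiophen-2-yl compound stands apart from the two furans.

On these data alone, it remains open whether thiophen-3-yl, a phenyl ring or a pyridine ring on the same carbonyl carbon would give a number near that of compound 1 or near those of the two furans. As far as these compounds go, it is also open whether a shorter chain between the amide nitrogen and the shared core would change the gap between thiophen-2-yl and the furans.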